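Swapping a Difluorophenyl for a Cyanophenyl: An Expected Outcome

The compounds below may be only part of what the source reports. "The series", "measured", "known", "first", "only" and "open" are said of these compounds alone.

Compound 1 `O=c1oc2ccccc2c(O)c1C(c1ccc(F)c(F)c1)c1c(O)c2ccccc2oc1=O` was tested in a functional assay on PANC-1 cells (Homo sapiens) for antiproliferative activity, read by MTT assay, with a stated time of 48 h (on this read-out higher numbers stand for weaker inhibition and lower numbers for stronger inhibition), where compound 1 gives 82.4 ug/mL. A second compound of a different build, compound 2 `CC(C)(C)c1ccc(C2C(C#N)=C(N)OC3=C2C(=O)CC3)cc1`, was run in the same assay; in this assay compound 2 gives 219 ug/mL. Of these two numbers, that of compound 1 is the lower, and the gap to compound 2 lies beyond the usual scatter of the method, so compound 1 is the stronger inhibitor of the pair as measured.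

Compound 3 `N#Cc1ccc(C(c2c(O)c3ccccc3oc2=O)c2c(O)c3ccccc3oc2=O)cc1` has not yet been measured. It differs from compound 1 in one place: 4-cyanophenyl in place of 3,4-difluorophenyl on a saturated chain carbon bound to two aromatic carbons. The shared core of compound 1 is kept unchanged. For the measured compounds named here, no measured pair shows what such a swap does on this core, and compound 2 stands in no single-point relation to either, so there is nothing to scale from. The expected step is a 1.0-fold lower number from compound 1 to compound 3 (0.01 log units; within the scatter), which is meant as none beyond the scatter. Compound 3 is therefore expected to give about 80 ug/mL in this assay, within a range from 40 ug/mL to 160 ug/mL.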

Compound 3, half-maximal inhibitory concentration: 93.5 ug/mL
Compound 3: middle estimate off by 1.2-fold (0.07 log units), on the low side; the range from low to high includes it.
By their numbers in this assay, from the lowest: compounds 1 and 3 (each within the scatter of the next); then compound 2.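

For the compounds shown here, this pair gives the first measured reading of a single change on the shared core: in this assay, 4-cyanophenyl in place of 3,4-difluorophenyl on a saturated chain carbon bound to two aromatic carbons gives a 1.1-fold higher number from compound 1 to compound 3 (0.05 log units; within the scatter), so the two compounds cannot be told apart on this read-out. At this place, then, a group carrying a nitrile and no fluorine can stand in for one carrying two fluorine atoms with no change beyond the scatter, even though the entering group brings a triple bond outside aromatic rings and a hydrogen-bond acceptor that the leaving group lacks. Nothing available explains why the two groups read alike, and the result itself gives no cause.

Going by these compounds alone, the pair covers only two substituted phenyl groups of equal heavy-atom count, so it leaves open whether this place would read the same with an amine or a carboxylic acid on the phenyl ring, or with a longer chain in place of that ring. It also leaves open whether any change at this place can move the number beyond the scatter on the shared core.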